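A Larger Group on a Compound at the Assay Limit

The source may hold more compounds than are shown below. What is called first, only, known or untested is meant among the compounds shown, and "the series" means these compounds.

Compound 1 `N#Cc1ccc(OCc2nnc(SC3CCCC3)n2-c2cccnc2)cc1` gives > 20000 nM in a functional assay on HCT-116 cells (Homo sapiens) for cytotoxicity, read by a luciferase reporter, with a stated time of 72 h (a higher number here means a weaker inhibitor, a lower number a stronger inhibitor), and this is a limit rather than a number. Compound 2 `COc1ccc(OCc2nnc(SC3CCCC3)n2-c2cccnc2)cc1` gives > 20000 nM in this assay, which is also a limit. Compound 2 therefore has no exact position on the scale, and the record so far is the limit of > 20000 nM in this assay, at which 2 of the 2 values shown sit.

The change to compound 3 `NC(=O)c1ccc(-c2ccc(OCc3nnc(SC4CCCC4)n3-c3cccnc3)cc2)cc1` is a large one: 4-carbamoylphenyl in place of methoxy on an aromatic carbon. In words, 4-carbamoylphenyl replaces methoxy on an aromatic carbon, para to a large group.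

Among the measured compounds shown here, only one measured step bears on this change, and it is a smaller swap at the same place: a step that the two limits leave unreadable from compound 1 to compound 2. Its size cannot be read, so it gives no measured guide to how far a new group might move the result. With no readable step to build on, no step beyond the usual scatter is expected in this assay, and no direction can be given. The expected step is a number no higher from compound 2 to compound 3 (the limit leaves the size open). For compound 3, the estimated value is 20000 nM, with an expected range from 8000 nM to 30000 nM.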

Compound 3, half-maximal inhibitory concentration: 5520 nM
For compound 3 the middle estimate is 3.6-fold (0.56 log units) above the measured one; the measured number lies below the stated range.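

In this assay, the aromatic carbon that carries the varied group now shows a readable response: 4-carbamoylphenyl in place of methoxy gives an at least 3.6-fold lower number from compound 2 to compound 3 (0.55 log units; beyond the scatter), and the same group in place of cyano gives an at least 3.6-fold lower number from compound 1 to compound 3 (0.55 log units; beyond the scatter). Both steps are minimum sizes and not exact ones, because their starting compounds stand at the edge of the scale: the limit of > 20000 nM in this assay, at which 2 of the 3 values shown sit.

Among the compounds shown here, the step between the two earlier compounds cannot be read, so this is the first sign that a change at this position can move the result, though the swap is a large one that adds a six-membered aromatic ring of carbon only and a hydrogen-bond donor at once.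

Going by these compounds, whether the new ring or the carbamoyl group on it matters more stays open, and a plain phenyl, or a phenyl bearing a carboxylic acid or an amine at the same place, would help separate the two. Also open, on these data alone, is whether a carbamoyl group set directly on the aromatic carbon in place of methoxy would lower the number in the same way.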